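A few compounds are considered here, and "the series" means these few. Any claim that something is new, unique, unknown or untested is made for them only; others in the source may bear on it.

Compound 1 `CC(C)n1cc(-c2ccnc3[nH]c(C4CCNCC4)cc23)ccc1=O`: in an ADME assay on cells (Hepatocyte, Rattus norvegicus) for metabolic stability (a lower number here means slower removal, a higher number faster removal of the compound), compound 1 sits at the assay limit, reported as < 1 uL/min.
Compound 2 `CNC(=O)CN1CCC(c2cc3c(-c4ccc(=O)n(C(C)C)c4)ccnc3[nH]2)CC1`: in this assay compound 2 gives 8.9 uL/min.
Compound 3 `CC(C)Cn1cc(-c2ccnc3[nH]c(C4CCN(CC(=O)N(C)C)CC4)cc23)ccc1=O`: in this assay compound 3 gives 6.6 uL/min.

Compound 3 stands at the lowest of the two numbers shown, and compound 2 lies within the scatter of it, so the two cannot be ordered. The value of compound 1 is a limit of the assay, not a number. Compound 4 `CC(C)n1cc(-c2ccnc3[nH]c(C4CCN(CC(=O)N(C)C)CC4)cc23)ccc1=O` has not yet been measured. It differs from compound 3 in one place: isopropyl in place of isobutyl on an aromatic nitrogen. Among the measured compounds shown here, the only measured step, an at least 8.9-fold higher number from compound 1 to compound 2 (0.94 log units; beyond the scatter), concerns an amine nitrogen in a ring and does not touch the group on the aromatic nitrogen. Compound 1 sits at the limit of < 1 uL/min in this assay, at which 1 of the 3 values shown sits. For the measured compounds named here, no measured step therefore bears on the exchange of isobutyl for isopropyl, and no step beyond the scatter is expected in this assay. Compound 4 is estimated to give 5 uL/min, in a range from 2 uL/min to 12 uL/min. The expected step is a 1.3-fold lower number from compound 3 to compound 4 (0.12 log units; within the scatter), which is estimated to remain within the scatter.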

Compound 4, intrinsic clearance in a liver preparation (reported as CLH), per the amount of preparation that the assay uses: 2.3 uL/min
Beside the measured number, compound 4's estimate is 2.2-fold (0.34 log units) above it, within the range that was stated.
By their numbers in this assay, from the lowest: compound 4; then compounds 3 and 2 (each within the scatter of the next). At a limit, below all of these: compound 1.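

In this assay, among the compounds shown here, compound 4 shows for the first time that the group on the aromatic nitrogen counts, since isopropyl in place of isobutyl gives a 2.9-fold lower number from compound 3 to compound 4 (0.46 log units; beyond the scatter). With isopropyl held constant, the end of the side chain on the amine nitrogen also counts: methyl in place of hydrogen on the amide-type nitrogen gives a 3.9-fold lower number from compound 2 to compound 4 (0.59 log units; beyond the scatter). The (dimethylcarbamoyl)methyl group in place of hydrogen on the amine nitrogen in a ring gives an at least 2.3-fold higher number from compound 1 to compound 4 (0.36 log units; beyond the scatter), and the size of that step is only a bound, since the entry for compound 1 is a limit of the assay: the limit of < 1 uL/min in this assay, at which 1 of the 4 values shown sits.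

The compounds shown leave open how a shorter chain such as ethyl, or a ring such as cyclopropyl, on the aromatic nitrogen would read in this assay. They also leave open how a carboxylic acid in place of the amide on the amine side chain would read there.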